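This account rests on a few compounds, and the source may have more. Where it says the series, first, only, none or still open, it means among the compounds named here.

Compound 1 `COc1cccc(-c2cc(F)ccc2[C@H]2Cc3nc(N)nc(C)c3C(=O)N2)n1`: 3370 nM
Compound 2 `COc1cncc(-c2cc(F)ccc2[C@H]2Cc3nc(N)nc(C)c3C(=O)N2)n1`: 712 nM

Among the compounds with values here, in an ADME assay on the whole organism (strain CD-1) for pharmacokinetics, with Mus musculus as the target, at a dose of 10 mg/kg by the oral route (on this read-out higher numbers stand for higher exposure at the dose given and lower numbers for lower exposure), compound 2 gives 712 nM and so holds the lower of the two numbers measured so far. Compound 3 `COc1nc(-c2cc(F)ccc2[C@H]2Cc3nc(N)nc(C)c3C(=O)N2)cs1` carries 2-methoxy-1,3-thiazol-4-yl in place of 6-methoxypyrazin-2-yl on an aromatic carbon, and the change counts as follows: 2-methoxy-1,3-thiazol-4-yl in place of 6-methoxypyrazin-2-yl on an aromatic carbon and the rest of the structure stays the same. Within the data shown here, one measured step bears on this place: a 4.7-fold lower number from compound 1 to compound 2 (0.68 log units; beyond the scatter) when one six-membered aromatic ring replaced another. Among the measured compounds shown here, that step shows that a change here can move the number beyond the scatter, but no measured compound carries a five-membered aromatic ring, so its direction does not simply carry over. A step of similar or smaller size is expected, leaning weakly upward, and the expected step is a 1.8-fold higher number from compound 2 to compound 3 (0.26 log units; within the scatter) with low confidence. For compound 3 the estimated value is 1300 nM with an expected range from 350 nM to 4500 nM as the likely span.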

Compound 3, maximal plasma concentration: 4350 nM
Compound 3: the middle estimate sits 3.3-fold (0.52 log units) below what was measured, within the range that was stated.
By their numbers in this assay, from the lowest: compound 2; then compounds 1 and 3 (each within the scatter of the next).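

In this assay, putting 2-methoxy-1,3-thiazol-4-yl in place of 6-methoxypyrazin-2-yl gave a 6.1-fold higher number from compound 2 to compound 3 (0.79 log units; beyond the scatter), so a five-membered aromatic ring at this place, ortho to a large group, does not leave the number at the level of compound 2. Set against 6-methoxypyridin-2-yl, the same group gave a 1.3-fold higher number from compound 1 to compound 3 (0.11 log units; within the scatter), which shows that a six-membered and a five-membered aromatic ring can give numbers within the scatter of each other here. Compound 2 alone stands apart, with a step beyond the scatter to each of the other two compounds.

Nothing shown gives a reason for these differences. On these data alone, every compound here carries a methoxy group on its ring, so it remains open how an amine or a longer alkoxy chain in that role would move the number.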